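From a Straight Chain to a Ring on the Amide Nitrogen

A few compounds are considered here, and "the series" means these few. Any claim that something is new, unique, unknown or untested is made for them only; others in the source may bear on it.

Of the compounds shown here, two have so far been measured in an assay on membranes from Sf9 cells for displacement of a labelled ligand from histamine H2 receptor (Homo sapiens), read by scintillation counting, with a stated time of 60 min; a lower number here means a stronger inhibitor, a higher number a weaker inhibitor. Compound 1 `COc1ccc(C(C)NC(=O)/N=C(\N)NCCCc2sc(N)nc2C)cc1` gives 37.2 nM in this assay. Compound 2 `CCCCCCNC(=O)/N=C(\N)Nc1cccc(-c2csc(N)n2)c1` gives 692 nM in this assay, the higher of the two numbers; its nearest neighbour is compound 1, and the gap between them lies beyond the usual scatter. Compound 3 `N/C(=N\C(=O)NC1CCCCC1)Nc1cccc(-c2csc(N)n2)c1` has not yet been measured. It differs from compound 2 in a single place: cyclohexyl in place of hexyl on an amide-type nitrogen. Going by the values given here, no measured pair in the set shows this particular exchange, so its effect cannot be read from the data. Since both groups leave and enter as carbon only, without donors or acceptors, the step from compound 2 to compound 3 is expected to be small, a 1.3-fold lower number from compound 2 to compound 3 (0.10 log units; within the scatter), and is not expected to reach beyond the scatter in either direction. Compound 3 is therefore estimated at 550 nM, within a range from 160 nM to 1900 nM.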

Compound 3, inhibition constant: 4470 nM
The estimate for compound 3 lay 8.1-fold (0.91 log units) below the measured number; the measured number lies above the stated range.
By their numbers in this assay, from the lowest: compound 1; then compound 2; then compound 3.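

On the amide-type nitrogen, exchanging hexyl for cyclohexyl leaves the counts of heavy atoms, donors and acceptors unchanged, yet in this assay it gives a 6.5-fold higher number from compound 2 to compound 3 (0.81 log units; beyond the scatter) on a shared core. This position therefore distinguishes a straight chain from a carbon-only ring, which could not be seen from compound 1 and compound 2, as they differ in more than one place. No measurement available here accounts for the size of this step.

From the compounds shown here alone, it remains open whether a smaller ring such as cyclopentyl or a branched chain such as isopropyl would stay close to compound 2 or to compound 3. The compounds shown also leave open whether a phenyl ring or a shorter chain such as butyl would be tolerated at this nitrogen, and whether the same exchange would have a similar effect on the core of compound 1.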